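Diamine core series: benzylamine variation in growth inhibition

This account rests on a few compounds, and the source may have more. Where it says the series, first, only, none or still open, it means among the compounds named here.

Measured so far:
compound 1 `Nc1cc(N)c2nc(-c3ccccc3)c(NCc3ccc(Cl)c(Cl)c3)nc2c1`, in a functional assay on OVCAR-4 cells (Homo sapiens) for inhibition, read by sulforhodamine B assay, with a stated time of 48 h (a higher number here means a weaker inhibitor of growth, a lower number a stronger inhibitor of growth), compound 1 gives 11700 nM
compound 2 `CCOC(=O)[C@H](CCC(=O)O)NC(=O)c1ccc(Sc2nc3cc(N)cc(N)c3nc2-c2ccccc2)cc1`, in this assay compound 2 gives 16600 nM
compound 3 `CCOC(=O)[C@H](CCC(=O)O)NC(=O)c1ccc(Oc2nc3cc(N)cc(N)c3nc2-c2ccccc2)cc1`, in this assay compound 3 gives 35500 nM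

Compound 1 holds the lowest number of the three in this assay. Its gap to compound 2 lies within the usual scatter, so no order between these two can be read. Its gap to compound 3 lies beyond the scatter, so compound 3 is the weaker growth inhibitor of that pair. All three carry the same core; they differ in what hangs on the linked nitrogen, sulfur or oxygen.

Compound 4 `COc1ccc(CNc2nc3cc(N)cc(N)c3nc2-c2ccccc2)cc1` has not yet been measured. It differs from compound 1 by 4-methoxyphenyl in place of 3,4-dichlorophenyl on a saturated chain carbon bound to a nitrogen on an aromatic ring. Going by the values given here, no measured pair isolates a change of this kind, so the data give no direct guide to its size. Compound 1 is the only benzylamine measured, and its number sets the anchor.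

In this assay the step from compound 1 to compound 4 is expected to be a 1.4-fold higher number from compound 1 to compound 4 (0.14 log units; within the scatter), a step no larger than the scatter, leaning toward a higher number.

For compound 4 in this assay the expected value is 16000 nM, with a range from 6000 nM to 42000 nM.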

Compound 4, concentration for 50% growth inhibition: 8130 nM
For compound 4 the middle estimate is 2.0-fold (0.29 log units) above the measured one; the range from low to high includes it.
By their numbers in this assay, from the lowest: compounds 4, 1 and 2 (each within the scatter of the next, the first and the last beyond it); then compound 3.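

In this assay, going by these compounds alone, the exchange of 3,4-dichlorophenyl for 4-methoxyphenyl on a saturated chain carbon bound to a nitrogen on an aromatic ring gives a 1.4-fold lower number from compound 1 to compound 4 (0.16 log units; within the scatter), the first measured step that isolates a change at this position. With compound 1 at 11700 nM and compound 4 at 8130 nM, no order can be read between these two benzylamines, even though the entering group has one hydrogen-bond acceptor and no chlorine, while the leaving group has no hydrogen-bond acceptor and two chlorine atoms. This single pair shows that this exchange leaves the growth inhibition within the scatter, but nothing measured here accounts for that result.

Still open, going by these compounds, is whether an unsubstituted phenyl, or a phenyl carrying an amine or a carboxylic acid, would stay within the scatter of compound 1 at this position. On these data alone, the effect of a longer chain in place of the saturated chain carbon also remains open.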